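Methylsulfonyl for isopropoxy on a sulfonamide aryl ring

This account rests on a few compounds, and the source may have more. Where it says the series, first, only, none or still open, it means among the compounds named here.

Measured so far:
compound 1, `Cc1c(C(=O)O)c(-c2cccc(N3CCN(c4ccc(NS(=O)(=O)c5ccc(N[C@H](CCN6CC(O)C6)CSc6ccccc6)c(S(=O)(=O)C(F)(F)F)c5)cc4)CC3)c2)c(-c2ccc(Cl)cc2)n1C`, 1.7 nM
compound 2, `Cc1c(C(=O)NCCCN2CCN(C)CC2)c(-c2cccc(N3CCN(c4ccc(NS(=O)(=O)c5cccc(OC(C)C)c5)cc4)CC3)c2)c(-c2ccc(Cl)cc2)n1C`, 522 nM
compound 3, `CCn1c(C)c(C(=O)O)c(-c2cccc(N3CCN(c4ccc(NS(=O)(=O)c5ccc(N[C@H](CCN6CCC(O)CC6)CSc6ccccc6)c(S(=O)(=O)C(F)(F)F)c5)cc4)CC3)c2)c1-c1ccc(Cl)cc1`, 1.2 nM

In an assay for binding affinity to Apoptosis regulator Bcl-2 (Homo sapiens), read by fluorescence polarization, with a stated time of 2 h (a lower number here means a stronger inhibitor, a higher number a weaker inhibitor), compound 2 gives 522 nM, the highest of the three numbers. Compound 1 gives 1.7 nM and compound 3 gives 1.2 nM; both gaps to compound 2 lie well beyond the scatter of this assay, and compound 2 is the weakest inhibitor of the three. Among the measured compounds shown here, compound 1 and compound 3 differ from compound 2 in several places at once, so no single step between measured compounds is available.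

Compound 4, `Cc1c(C(=O)NCCCN2CCN(C)CC2)c(-c2cccc(N3CCN(c4ccc(NS(=O)(=O)c5cccc(S(C)(=O)=O)c5)cc4)CC3)c2)c(-c2ccc(Cl)cc2)n1C`, is the unmeasured compound. It differs from compound 2 in one place: methylsulfonyl in place of isopropoxy on an aromatic carbon. For the measured compounds named here, no measured pair shows what this exchange does in this assay. A step of modest size is expected, in either direction, and quite possibly none beyond the scatter, so the estimate for the step from compound 2 to compound 4 is a 1.3-fold higher number from compound 2 to compound 4 (0.13 log units; within the scatter). Compound 4 is accordingly expected to give about 700 nM in this assay, with a range from 200 nM to 2500 nM.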

Compound 4, inhibition constant: 658 nM
Compound 4: middle estimate off by 1.1-fold (0.03 log units), on the high side; measured number inside the range.
By their numbers in this assay, from the lowest: compounds 3 and 1 (each within the scatter of the next); then compounds 2 and 4 (each within the scatter of the next).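

Methylsulfonyl in place of isopropoxy on this aromatic carbon, meta to a large group, gives a 1.3-fold higher number from compound 2 to compound 4 (0.10 log units; within the scatter) in this assay. This single-place exchange shows that, in the setting of compound 2, the two groups cannot be told apart in this read-out, even though methylsulfonyl carries more hydrogen-bond acceptors and brings in sulfur. The earlier compounds shown here could not show this, since compound 1 and compound 3 differ from compound 2 in several places at once. Nothing at hand explains why the two groups read alike.

Going by these compounds, whether an amine or a carboxylic acid on this carbon would also read alike remains open. So does whether the same exchange would leave the number unmoved on the core of compound 1 or compound 3.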